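This account rests on a few compounds, and the source may have more. Where it says the series, first, only, none or still open, it means among the compounds named here.

The two measured compounds and their numbers:

- Compound 1, `COc1ccc(-c2nc3ncccc3o2)cc1`, gives 14%
- Compound 2, `FC(F)(F)c1ccccc1-c1nc2ncccc2o1`, gives 19%

Both numbers come from a functional assay on the whole organism for inhibition, with Rattus norvegicus as the target, at a dose of 30 mg/kg; a higher number here means more inhibition at the dose given (going by the name of the read-out), a lower number less inhibition. In this assay compound 2 gives 19%, the higher of the two numbers, and its nearest neighbour is compound 1, whose number lies only slightly lower, a gap that sits within the usual scatter of repeated measurements. Within the data shown here, no pair of measured compounds differs in only one place, so no single structural change has yet been tied to a measured step.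

The next compound to be measured is compound 3, `c1ccc(-c2nc3ncccc3o2)cc1`. It differs from compound 2 in one place: hydrogen in place of trifluoromethyl on an aromatic carbon. Among the measured compounds shown here, nothing measured so far shows what removing the trifluoromethyl does in this assay, so the expectation rests only on the two numbers already seen, which lie close together. The step from compound 2 to compound 3 is expected to be small, most likely downward or no larger than the scatter: a number 6 percentage points lower from compound 2 to compound 3 (within the scatter). Compound 3 is therefore estimated to give 13%, with a range from 0% to 30%.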

Compound 3, a percentage reported as inhibition, in the whole organism at one dose (the size of the read-out at that dose, not a potency): 41%
Compound 3: the middle estimate sits 28 percentage points below what was measured; measured number outside the range, above it.
By their numbers in this assay, from the lowest: compounds 1 and 2 (each within the scatter of the next); then compound 3.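

In this assay, putting hydrogen in place of trifluoromethyl on an aromatic carbon gives a number 22 percentage points higher from compound 2 to compound 3 (beyond the scatter) and putting hydrogen in place of methoxy gives a number 27 percentage points higher from compound 1 to compound 3 (beyond the scatter) in the same direction. Among these compounds, the earlier pair could not show this, as its two compounds differ in more than one place and stand within the scatter of each other; compound 3, with neither group, is the first to stand clearly apart from both. Among these three compounds, then, the higher inhibition goes with the ring carrying hydrogen alone, and neither of the two groups goes against that pattern, although they cannot be ranked against each other.

No measurement here bears on why removing either group goes with more inhibition. On these data alone, whether every replacement of hydrogen on this ring lowers the number remains open, since a single fluorine atom, a methyl, an amine or a carboxylic acid could each behave differently from trifluoromethyl and methoxy, and a reading at one dose leaves the potency of all three compounds unknown.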